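Compound 2 to compound 4: isobutyl gives way to phenoxy

This account rests on a few compounds, and the source may have more. Where it says the series, first, only, none or still open, it means among the compounds named here.

Measured in a physicochemical assay for solubility, with a stated time of 18 h, at pH 7.4; on this read-out higher numbers stand for higher solubility and lower numbers for lower solubility:
- compound 1 `COc1cccc(CNCCCNc2ccnc3cc(-c4ccc(F)cc4)ccc23)c1O`: 32000 nM
- compound 2 `CC(C)Cc1ccc2c(NCCCNCc3ccco3)ccnc2c1`: 4200 nM
- compound 3 `COc1cccc(CNCCCNc2ccnc3cc(-c4ccc(C(C)(C)C)cc4)ccc23)c1O`: 32000 nM

Compound 2, at 4200 nM, stands lowest of the three in this assay. Compound 1 with 32000 nM and compound 3 with 32000 nM both lie above it, beyond the usual scatter.

The next compound to be measured is compound 4 `c1ccc(Oc2ccc3c(NCCCNCc4ccco4)ccnc3c2)cc1`, which departs from compound 2 through one change: phenoxy in place of isobutyl on an aromatic carbon. In other words, phenoxy stands in place of isobutyl on an aromatic carbon.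

Going by the values given here, only one measured step bears on this change, and it does so loosely: no change at the digits printed from compound 1 to compound 3 (within the scatter), where tert-butyl takes the place of fluoro on an aromatic carbon. That step involves neither isobutyl nor phenoxy, and compounds 1 and 3 also differ from compound 2 elsewhere in their structures. Among the compounds with values here, no measured step shows what this exact exchange does. Within the data shown here, with that single flat step as the only guide, no shift beyond the scatter is expected in this assay, and no direction can be favoured.

The estimated change is small: a 1.1-fold higher number from compound 2 to compound 4 (0.03 log units; within the scatter). Compound 4 is expected at 4500 nM, within an estimated range of 1500 nM to 14000 nM.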

Compound 4, solubility: 14500 nM
Estimate against measurement, compound 4: 3.2-fold (0.51 log units) below, outside the stated range (above it).
By their numbers in this assay, from the lowest: compound 2; then compound 4; then compounds 1 and 3 (each within the scatter of the next).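

In this assay, the exchange at this aromatic carbon does register: phenoxy in place of isobutyl gives a 3.5-fold higher number from compound 2 to compound 4 (0.54 log units; beyond the scatter), a modest step, and the only step shown here that lies beyond the scatter. Going by these compounds alone, the one earlier step, no change at the digits printed from compound 1 to compound 3 (within the scatter), showed that an exchange on an aromatic carbon can leave the number unmoved, and it did so on a different parent, so the present pair shows that such a flat result does not hold for every exchange of this kind. No measurement offered here accounts for the step, which stands as an observation on this single pair.

As far as these compounds go, what remains open is which part of the change goes with the higher number, since phenoxy brings a six-membered aromatic ring, an oxygen and more heavy atoms all at once. A methoxy group or a benzyl group on the same aromatic carbon would begin to separate the oxygen from the ring, and whether the step would carry over to the parent of compound 1 also remains unanswered by the compounds shown.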